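A few compounds are considered here, and "the series" means these few. Any claim that something is new, unique, unknown or untested is made for them only; others in the source may bear on it.

Compound 1 `CCC(CC)n1c(-c2ccc(OCc3c(-c4c(Cl)cccc4Cl)noc3C(C)C)cc2)nc2ccc(C(=O)O)cc21`: 5690 nM
Compound 2 `CC(C)c1onc(-c2c(Cl)cccc2Cl)c1COc1ccc(-c2nc3ccc(C(=O)O)cc3n2CC(C)(C)C)cc1`: 861 nM
Compound 3 `CCCC(CCC)n1c(-c2ccc(OCc3c(-c4c(Cl)cccc4Cl)noc3C(C)C)cc2)nc2ccc(C(=O)O)cc21`: > 10000 nM

All three compounds share one core and differ only in the chain on the aromatic nitrogen. In an assay on HEK-293T cells for antagonist activity at vitamin D3 receptor (Homo sapiens), read by a luciferase reporter, with a stated time of 24 h (on this read-out higher numbers stand for weaker inhibition and lower numbers for stronger inhibition), compound 2 gives 861 nM, while compound 1 gives 5690 nM. For compound 3 the assay reports only a limit, > 10000 nM, not a number. Compound 3 therefore stands at the limit of > 10000 nM in this assay, at which 1 of the 3 values shown sits. The measured steps were a 6.6-fold lower number from compound 1 to compound 2 (0.82 log units; beyond the scatter), an at least 11-fold higher number from compound 2 to compound 3 (1.06 log units; beyond the scatter) and an at least 1.7-fold higher number from compound 1 to compound 3 (0.24 log units; that floor lies within the scatter).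

Compound 4 `CC(C)c1onc(-c2c(Cl)cccc2Cl)c1COc1ccc(-c2nc3ccc(C(=O)O)cc3n2C(C)C)cc1` carries isopropyl in place of 1-propylbutyl on an aromatic nitrogen. Within the data shown here, the steps that bear on it are those into and out of compound 3, since they also swap the chain on this nitrogen. The swap from compound 2 to compound 3 was large and went upward, and compound 4 now moves to the smallest chain in the set. The number for compound 4 is therefore expected to fall, by roughly an at least 6.6-fold lower number from compound 3 to compound 4 (0.82 log units; beyond the scatter). Compound 4 is estimated at 1500 nM, with a range from 400 nM to 6000 nM.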

Compound 4, half-maximal inhibitory concentration: 3550 nM
The estimate for compound 4 lay 2.4-fold (0.37 log units) below the measured number, and the stated range covers the measured number.
By their numbers in this assay, from the lowest: compound 2; then compounds 4 and 1 (each within the scatter of the next). At a limit, above all of these: compound 3.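

In this assay, isopropyl and pentan-3-yl on this aromatic nitrogen cannot be told apart, as a 1.6-fold lower number from compound 1 to compound 4 (0.20 log units; within the scatter) shows, so trimming that branched chain down to the smallest one in the set brings no measurable gain. Neopentyl keeps a clear lead over isopropyl, with a 4.1-fold higher number from compound 2 to compound 4 (0.62 log units; beyond the scatter), so the numbers on this nitrogen do not simply follow chain size, and compound 2 is the one that breaks any rule of smaller being better. The 1-propylbutyl chain does still give way to isopropyl, with an at least 2.8-fold lower number from compound 3 to compound 4 (0.44 log units; beyond the scatter), though this is only a floor, as its starting point is a limit: the limit of > 10000 nM in this assay, at which 1 of the 4 values shown sits.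

What the compounds shown leave open is how a straight chain such as n-butyl would behave here. From the compounds shown here alone, a ring such as cyclohexyl, or a chain ending in an amine, is equally open.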